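This account rests on a few compounds, and the source may have more. Where it says the series, first, only, none or still open, it means among the compounds named here.

Measured so far in a functional assay on CCRF-CEM cells (Homo sapiens) for cytotoxicity, in the presence of a further agent that is not named here; a higher number here means a weaker inhibitor, a lower number a stronger inhibitor:
compound 1 `Nc1nc(N)c(CCCNc2cc(F)c(F)cc2[N+](=O)[O-])c(O)n1`: 97000 nM
compound 2 `Nc1nc(N)c(CCCNc2cc(F)cc(F)c2[N+](=O)[O-])c(O)n1`: 94000 nM
compound 3 `COC(=O)c1ccc(CN(CCCc2c(N)nc(N)nc2O)c2cc(F)c(F)cc2[N+](=O)[O-])cc1`: 53000 nM

Of the three numbers, that of compound 1 is the highest, but its gaps to compound 2 and to compound 3 both lie within the scatter, so nothing separates the three. Compound 4 `Nc1nc(N)c(CCCNc2cc(F)c([N+](=O)[O-])cc2[N+](=O)[O-])c(O)n1` derives from compound 1 by nitro in place of fluoro on an aromatic carbon. Among the compounds with values here, the only known step, a 1.8-fold lower number from compound 1 to compound 3 (0.26 log units; within the scatter), concerns another place and another change and was itself within the scatter; no measured step exchanges fluoro for nitro. Compound 1 and compound 2, which differ only in where the fluoro groups sit, give values within the scatter of each other. Within the data shown here, with no bearing step, compound 4 is expected to move by a 1.2-fold lower number from compound 1 to compound 4 (0.08 log units; within the scatter), no more than the scatter. Compound 4 is thus estimated at 80000 nM, within 30000 nM to 200000 nM in this assay.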

Compound 4, half-maximal inhibitory concentration: 1200 nM
For compound 4 the middle estimate is 67-fold (1.82 log units) above the measured one; the whole stated range lies above it.
By their numbers in this assay, from the lowest: compound 4; then compounds 3, 2 and 1 (each within the scatter of the next).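

In this assay, within the data shown here, nitro in place of fluoro para to a large group gives an 81-fold lower number from compound 1 to compound 4 (1.91 log units; beyond the scatter), the only step so far beyond the scatter. Among these compounds, compound 1 and compound 2 stand within the scatter of each other, and so does the pair in a 1.8-fold lower number from compound 1 to compound 3 (0.26 log units; within the scatter), so this place and this change are the first to register. Nothing measured here bears on the cause of the step.

On these data alone, whether an amine or a carboxylic acid in this place gives a comparable step stays open. So does whether the step holds in compounds carrying 4-(methoxycarbonyl)benzyl on the nitrogen, or a longer chain.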